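Compound 2 to compound 3: methoxy in place of fluoro

The source may hold more compounds than are shown below. What is called first, only, known or untested is meant among the compounds shown, and "the series" means these compounds.

In a functional assay on MCF7 cells (Homo sapiens) for antiproliferative activity, read by sulforhodamine B assay, with a stated time of 72 h (a lower number here means a stronger inhibitor, a higher number a weaker inhibitor), compound 1 (`COc1c(OC(C)C)cc2ccc(-c3cc(=O)c4ccccc4o3)cc2c1OC(C)C`) gives > 10000 nM as its result, and this is a limit and not a number. In this assay compound 2 (`O=C(/C=C/c1csc2ccccc12)c1cc(F)ccc1O`) gives > 10000 nM as its result, and this too is only a limit. Compound 2 therefore stands at the limit of > 10000 nM in this assay, at which 2 of the 2 values shown sit, and has no numerical value of its own.

Compound 3 (`COc1ccc(O)c(C(=O)/C=C/c2csc3ccccc23)c1`) has not yet been measured. It has methoxy in place of fluoro on an aromatic carbon, meta to a large group and para to a hydroxy group. Among the compounds with values here, no step between measured compounds is available, so the series offers no measured size for a change of this kind. With compound 2 reported as > 10000 nM and no number to start from, the expectation is that the result stays close to the limit. The expected change, a step that the limit leaves unreadable from compound 2 to compound 3, is estimated to lie within the scatter, with no direction expected. For compound 3 the estimate is 12000 nM with an expected range from 4000 nM to 30000 nM in this assay, and a result reported only as a limit is the likeliest outcome.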

Compound 3, half-maximal inhibitory concentration: 750 nM
Compound 3: middle estimate off by 16-fold (1.20 log units), on the high side; the measured number lies below the stated range.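

In this assay, methoxy in place of fluoro on an aromatic carbon, meta to a large group and para to a hydroxy group, gives an at least 13-fold lower number from compound 2 to compound 3 (1.12 log units; beyond the scatter). This position is therefore not silent: a change of a single substituent here is enough to bring the series from the limit to a readable number, which neither compound 1 nor compound 2 could show, and compound 1 differs from the other two in more than one place and offers no comparison. Compound 2 has no number of its own, so the step fixes only a minimum size and its full size stays unknown: the limit of > 10000 nM in this assay, at which 2 of the 3 values shown sit.

With a single step at this position, the compounds shown cannot separate what is particular to methoxy from what any replacement of fluoro might do, and they give no reading on whether a longer chain such as ethoxy, an amine or a plain hydrogen at the same carbon would hold the gain. The role of the hydroxy group para to this position also stays open, as no step among these compounds changes it.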